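A few compounds are considered here, and "the series" means these few. Any claim that something is new, unique, unknown or untested is made for them only; others in the source may bear on it.

In an ADME assay on RAW264.7 cells (Mus musculus) for cytotoxicity, read by MTT assay, with a stated time of 24 h (on this read-out higher numbers stand for lower toxicity in this test and lower numbers for higher toxicity in this test), compound 1 `Cc1ccc(C2=NN(C3=NC(=O)CS3)C(c3ccccc3C)C2)cc1C` gives 317000 nM and compound 2 `Cc1ccc(C2=NN(C3=NC(=O)CS3)C(c3ccc(Cl)cc3)C2)cc1C` gives 226000 nM. Among the compounds with values here, compound 2 therefore stands within the scatter of compound 1, the only other compound measured so far, and the two cannot be told apart on these numbers. Compound 3 `Cc1ccc(C2=NN(C3=NC(=O)CS3)C(c3cccc(Cl)c3)C2)cc1C` has 3-chlorophenyl in place of 4-chlorophenyl on a saturated ring carbon. Within the data shown here, one measured step bears on this change: a 1.4-fold lower number from compound 1 to compound 2 (0.15 log units; within the scatter), which swapped 4-chlorophenyl for 2-methylphenyl on that carbon and stayed within the scatter. A single step is thin evidence, but it gives no reason to expect a shift beyond the scatter in this assay, and no direction is favoured. The estimated step is a 1.1-fold higher number from compound 2 to compound 3 (0.04 log units; within the scatter). The expected value for compound 3 is 250000 nM, with an estimated range from 130000 nM to 450000 nM.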

Compound 3, half-maximal cytotoxic concentration: 178000 nM
Compound 3: middle estimate off by 1.4-fold (0.15 log units), on the high side; the range from low to high includes it.
By their numbers in this assay, from the lowest: compounds 3, 2 and 1 (each within the scatter of the next).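

Moving the chlorine on the phenyl ring at the saturated ring carbon, with 3-chlorophenyl in place of 4-chlorophenyl, gives in this assay a 1.3-fold lower number from compound 2 to compound 3 (0.10 log units; within the scatter), so this change of attachment pattern, with the same atoms, does not separate the two compounds. Putting 3-chlorophenyl in place of 2-methylphenyl gives a 1.8-fold lower number from compound 1 to compound 3 (0.25 log units; within the scatter), so all three substituted phenyl groups on this carbon now lie within the scatter of one another, and none can be ranked in this test. Nothing available explains these numbers or links them to any property of the groups.

The compounds shown carry only chlorophenyl or methylphenyl groups on this carbon, so it remains open whether a phenyl ring bearing an amine or a carboxylic acid, or a longer alkyl chain in its place, would move the number beyond the scatter. On these data alone, the 3,4-dimethylphenyl group is the same throughout, so its contribution also remains open.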